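The source may hold more compounds than are shown below. What is called first, only, known or untested is meant among the compounds shown, and "the series" means these compounds.

Of the three compounds measured in an assay on Sf9 cells for inhibition of 1-acyl-sn-glycerol-3-phosphate acyltransferase beta (Homo sapiens) (a lower number here means a stronger inhibitor, a higher number a weaker inhibitor), compound 3 `CCOc1ccc(Br)cc1-c1cc(Nc2ccc(C(N)=O)cc2)nc(N)n1` gives 750 nM, the highest of the three numbers. Compound 2 `CCOc1ccc(Br)cc1-c1cc(Nc2cccc(C#N)c2)nc(N)n1` gives 720 nM in this assay, within the scatter of compound 3, while compound 1 `COc1ccc(Cl)cc1-c1cc(Nc2ccc(Cl)cc2)nc(N)n1` gives 54 nM, a gap beyond the scatter. Compound 4 `CCOc1ccc(Br)cc1-c1cc(Nc2ccc(C(C)=O)cc2)nc(N)n1` differs from compound 3 by methyl in place of amino on a carbonyl carbon. For the measured compounds named here, no measured step touches the carbonyl carbon; the only single-point step, a 1.0-fold higher number from compound 2 to compound 3 (0.02 log units; within the scatter), exchanged the aryl group on the nitrogen and stayed within the scatter. With nothing closer to rest on, a step no larger than the scatter is expected from the change to the acetyl group. Compound 4 is therefore expected at 700 nM, range 300 nM to 1600 nM. The expected step is a 1.1-fold lower number from compound 3 to compound 4 (0.03 log units; within the scatter).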

Compound 4, half-maximal inhibitory concentration: 34 nM
Compound 4: middle estimate off by 21-fold (1.31 log units), on the high side; measured number outside the range, below it.
By their numbers in this assay, from the lowest: compounds 4 and 1 (each within the scatter of the next); then compounds 2 and 3 (each within the scatter of the next).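

In this assay the exchange on the carbonyl carbon gives a large step (a 22-fold lower number from compound 3 to compound 4 (1.34 log units; beyond the scatter)) from a change of one heavy atom, so this place is far from indifferent. The aryl group on the nitrogen is not flat either: 4-acetylphenyl in place of 3-cyanophenyl gives a large step (a 21-fold lower number from compound 2 to compound 4 (1.33 log units; beyond the scatter)), whereas 4-carbamoylphenyl in that place stays within the scatter (a 1.0-fold higher number from compound 2 to compound 3 (0.02 log units; within the scatter)). No evidence bears on what lies behind this step. From the compounds shown here alone, whether the gain depends on the methyl itself stays open; a propanoyl group, a methyl ester or a carboxylic acid in place of the acetyl group would test this.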